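A Halogen Swap at the Aryl Ether of a Bicyclic Core

The source may hold more compounds than are shown below. What is called first, only, known or untested is meant among the compounds shown, and "the series" means these compounds.

The series rests on one shared core, seen in compound 1 `NC1=NC2(CCOCC2)N(OCCCOc2ccccc2)C(N)=N1` and compound 2 `NC1=NC2(CCOCC2)N(OCCCOc2ccc(Cl)c(Cl)c2)C(N)=N1`, which differ only in the aromatic group carried on an oxygen on a saturated carbon. In an assay on isolated protein for inhibition of Dihydrofolate reductase (Homo sapiens), read by spectrophotometry, using NADPH, with stated times of 5 s and 6 min, tested at 5 uM (on this read-out higher numbers stand for a stronger effect at the one concentration tested and lower numbers for a weaker effect), compound 1 gives > 90%, which is a limit of the assay rather than a number. In this assay compound 2 likewise gives > 90%, again a limit. The change between them is a step that the two limits leave unreadable from compound 1 to compound 2, so the step cannot be read. Compound 2 therefore stands at the upper edge of what the assay reports, as does every value shown, since (the limit of > 90% in this assay, at which 2 of the 2 values shown sit).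

Compound 3 `NC1=NC2(CCOCC2)N(OCCCOc2ccccc2Br)C(N)=N1` is the next step from compound 2, with 2-bromophenyl in place of 3,4-dichlorophenyl on an oxygen on a saturated carbon. Going by the values given here, the only measured step that bears on this aryl position is the one from compound 1 to compound 2, and it is unreadable; it nonetheless shows that both a phenyl and a 3,4-dichlorophenyl at this oxygen sit at the limit. Compound 3 is thus expected to stay at that limit, an estimated step that the limit leaves unreadable from compound 2 to compound 3, with compound 3 estimated at 92%, between 80% and 100%.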

Compound 3, a percentage reported as inhibition, at one concentration (the size of the read-out at that concentration, not a potency): 83.8%
Beside the measured number, compound 3's estimate is 8.2 percentage points above it; low and high end bracket the measured number.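

Going by these compounds alone, compound 3 is the first compound in this group to give a number rather than a limit in this assay, so this aryl group now has a reading that is not pinned to the top of what is reported: the limit of > 90% in this assay, at which 2 of the 3 values shown sit. The change to 2-bromophenyl in place of 3,4-dichlorophenyl is a number at least 6.2 percentage points lower from compound 2 to compound 3 (that floor lies within the scatter), and the change of bromo in place of hydrogen on an aromatic carbon is a number at least 6.2 percentage points lower from compound 1 to compound 3 (that floor lies within the scatter). Both steps are known only by a floor, so neither shows a real loss of effect, and the step between the two compounds at the limit still cannot be read.

The compounds shown leave open whether the reading follows the identity of the halogen or where it stands on the ring, which a 2-chlorophenyl or a 4-bromophenyl group would help to separate. They also leave open how the reading moves with an amine on the aromatic ring, or with a longer chain in place of the saturated chain that carries the oxygen.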